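Swapping a sulfonamide arm for difluorophenyl on the triazole

The source may hold more compounds than are shown below. What is called first, only, known or untested is meant among the compounds shown, and "the series" means these compounds.

Compound 2 `Cc1ccc(S(=O)(=O)NCc2cn(C[C@H](O)[C@H]3OC(=O)C(OCc4ccccc4)=C3OCc3ccccc3)nn2)cc1` gives 14400 nM in a functional assay on HeLa cells (Homo sapiens) for antiproliferative activity, read by MTT assay, with a stated time of 72 h (a higher number here means a weaker inhibitor, a lower number a stronger inhibitor), the lower of the two plain numbers seen here. Compound 3 `O=C1O/C(=C\Cn2cc(-c3cc(F)cc(F)c3)nn2)C(OCc2ccccc2)=C1OCc1ccccc1` gives 17700 nM in this assay, which lies within the scatter of compound 2. Compound 1 `COc1ccc(-c2cn(C/C=C3\OC(=O)C(OCc4ccccc4)=C3OCc3ccccc3)nn2)cc1` reports only a limit in this assay, > 100000 nM, as shown by the limit of > 100000 nM in this assay, at which 1 of the 3 values shown sits.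

Compound 4 `O=C1O[C@H]([C@@H](O)Cn2cc(-c3cc(F)cc(F)c3)nn2)C(OCc2ccccc2)=C1OCc1ccccc1` differs from compound 2 by 3,5-difluorophenyl in place of (((4-methylphenyl)sulfonyl)amino)methyl on an aromatic carbon. Among the compounds with values here, the one measured step that bears on this change, an at least 5.6-fold lower number from compound 1 to compound 3 (0.75 log units; beyond the scatter), brought in the same 3,5-difluorophenyl, though on a different core, and compound 3, which already carries that group, sits close to compound 2. A small change is therefore expected, a 1.0-fold higher number from compound 2 to compound 4 (0.02 log units; within the scatter), within the scatter. Compound 4 is estimated at 15000 nM, ranging from 5000 nM to 45000 nM.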

Compound 4, half-maximal inhibitory concentration: 40800 nM
Compound 4: the middle estimate sits 2.7-fold (0.43 log units) below what was measured; the measured number falls inside the stated range.
By their numbers in this assay, from the lowest: compounds 2 and 3 (each within the scatter of the next); then compound 4. At a limit, above all of these: compound 1.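

On the core shared by the two compounds, 3,5-difluorophenyl in place of (((4-methylphenyl)sulfonyl)amino)methyl brings a 2.8-fold higher number from compound 2 to compound 4 (0.45 log units; beyond the scatter), so here the swap gives a weaker inhibitor. Until now, 3,5-difluorophenyl had only lowered the number, on a different core and in place of 4-methoxyphenyl, and that gain does not carry over to this core. Nothing measured here explains the step. Still open, from the compounds shown here alone, is how a simple aminomethyl group on this aromatic carbon would compare, which would help show whether the sulfonyl and 4-methylphenyl parts matter.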